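The source may hold more compounds than are shown below. What is called first, only, known or untested is meant among the compounds shown, and "the series" means these compounds.

Measured so far in a functional assay on MCF7 cells (Homo sapiens) for inhibition, read by sulforhodamine B assay; on this read-out higher numbers stand for weaker inhibition and lower numbers for stronger inhibition:
compound 1, `Cc1ccc(NC2=CC(=O)c3nc4n(c3C2=O)[C@H]2OC[C@@H](O)[C@H]2OC4)cc1`: 1660 nM
compound 2, `COc1cccc(NC2=CC(=O)c3c(nc4n3[C@H]3OC[C@@H](O)[C@H]3OC4)C2=O)c1`: 3830 nM
compound 3, `O=C1C(Nc2cccc(Cl)c2)=CC(=O)c2c1nc1n2[C@H]2OC[C@@H](O)[C@H]2OC1`: 2970 nM

All three numbers sit within the scatter of one another, so compound 3 is not set apart from compound 1 or compound 2 by these values. Within the data shown here, the only single-point step among them, a 1.3-fold lower number from compound 2 to compound 3 (0.11 log units; within the scatter), swaps one aryl substituent on the amine nitrogen and moves nothing beyond the scatter.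

Compound 4, `CCCc1ccc(NC2=CC(=O)c3c(nc4n3[C@H]3OC[C@@H](O)[C@H]3OC4)C2=O)cc1`, differs from compound 3 in one place: 4-propylphenyl in place of 3-chlorophenyl on an amine nitrogen. Among the measured compounds shown here, the closest precedent is the same kind of aryl swap on that nitrogen, which gave the flat step above, and compound 1, which carries a 4-methylphenyl there, also lies in the same band. No step beyond the scatter is therefore expected: for compound 4 the estimate in this assay is 2000 nM, range 800 nM to 5000 nM, corresponding to an expected 1.5-fold lower number from compound 3 to compound 4 (0.17 log units; within the scatter).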

Compound 4, half-maximal inhibitory concentration: > 4000 nM
Compound 4 ended at the assay's limit (the forecaster's own chance of this, stated with the estimate: 5%); at least 2.0-fold (0.30 log units) between middle value and limit.
By their numbers in this assay, from the lowest: compounds 1, 3 and 2 (each within the scatter of the next, the first and the last beyond it). At a limit, above all of these: compound 4.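

In this assay compound 4 gives > 4000 nM, a limit of the assay and not a number. Among these compounds, it is the first aryl swap on this amine nitrogen without a measured value, whereas the earlier compounds all carry numbers. The floors, an at least 1.3-fold higher number from compound 3 to compound 4 (0.12 log units; that floor lies within the scatter) and an at least 1.0-fold higher number from compound 2 to compound 4 (0.01 log units; that floor lies within the scatter), lie within the scatter, so 4-propylphenyl is not shown to differ from 3-chlorophenyl or 3-methoxyphenyl here.

As far as these compounds go, the actual value of compound 4 remains open. Also open, from the compounds shown here alone, is how a phenyl ring bearing an amine or a carboxylic acid would read on this nitrogen.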